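The compounds below may be only part of what the source reports. "The series", "measured", "known", "first", "only" and "open" are said of these compounds alone.

Compound 1 `Cc1ccc2oc(=O)c(C(=O)NCc3ccccc3)cc2c1` in an assay on isolated protein for inhibition of coagulation factor XII (Homo sapiens); on this read-out lower numbers stand for stronger inhibition and higher numbers for weaker inhibition: > 50000 nM, which is a limit of the assay rather than a number.
Compound 2 `Cc1cccc(NC(=O)c2cc3cc(C)ccc3oc2=O)c1` in this assay: 10000 nM.

Compound 2 thus holds the only number shown; the one further value is a limit (the limit of > 50000 nM in this assay, at which 1 of the 2 values shown sits). Within the data shown here, the single measured step runs an at least 5.0-fold lower number from compound 1 to compound 2 (0.69 log units; beyond the scatter), when a 3-methylphenyl replaced a benzyl on the amide-type nitrogen.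

Compound 3 `Cc1ccc2oc(=O)c(C(=O)Nc3ccccc3Cl)cc2c1` changes that same position again: 2-chlorophenyl in place of 3-methylphenyl on an amide-type nitrogen. Among the measured compounds shown here, only the step from compound 1 to compound 2 bears on it, and only loosely, since it swapped a benzyl for an aryl group, whereas here one aryl group replaces another on the same nitrogen. No step beyond the scatter is therefore expected in this assay, though a limit cannot be ruled out given how weak compound 2 already is. The expected step is no change at the digits printed from compound 2 to compound 3 (within the scatter). Compound 3 is estimated at 10000 nM, within 3000 nM to 40000 nM.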

Compound 3, half-maximal inhibitory concentration: 30000 nM
The estimate for compound 3 lay 3.0-fold (0.48 log units) below the measured number; measured number inside the range.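

Replacing one aryl group with another on the amide-type nitrogen is not a neutral change: in this assay there is a 3.0-fold higher number from compound 2 to compound 3 (0.48 log units; beyond the scatter). The gain seen on moving from benzyl to 3-methylphenyl therefore depends on which aryl group enters, and 2-chlorophenyl keeps less of it. The comparison with benzyl is also less clear here, with an at least 1.6-fold lower number from compound 1 to compound 3 (0.22 log units; that floor lies within the scatter), so 2-chlorophenyl cannot be said to improve on benzyl. Compound 1 remains a limit of the assay rather than a number: the limit of > 50000 nM in this assay, at which 1 of the 3 values shown sits.

The two aryl groups differ in both the substituent and the number in its name, so these two compounds cannot separate the two changes. On these data alone, what 3-chlorophenyl or 2-methylphenyl would give remains open, as does the effect of an amine or a carboxylic acid on the aryl ring.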